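Moving the aryl substituent back around the ring

The source may report more compounds than this note shows. Statements on the series, on what has been measured and on what is new or still open speak of the compounds shown alone.

The shared core, carrying a 4-nitrophenyl group, is compound 1 `O=C(Cn1cc(-c2ccc([N+](=O)[O-])cc2)nn1)Nc1nc2ccccc2s1`; in a functional assay on BMDM cells (Mus musculus, strain C57BL/6) for inhibition, with a stated time of 2 days (a lower number here means a stronger inhibitor, a higher number a weaker inhibitor), compound 1 gives 3280 nM. Compound 2 `O=C(Cn1cc(-c2ccccc2Cl)nn1)Nc1nc2ccccc2s1` carries a 2-chlorophenyl group instead. In this assay compound 2 reaches only > 30000 nM, which is a limit of the assay and not a number, so it stands on (the limit of > 30000 nM in this assay, at which 1 of the 2 values shown sits). Among the measured compounds shown here, the single measured step, an at least 9.1-fold higher number from compound 1 to compound 2 (0.96 log units; beyond the scatter), is therefore known only as a lower bound. Compound 3 `COc1ccc(-c2cn(CC(=O)Nc3nc4ccccc4s3)nn2)cc1` differs from compound 2 by 4-methoxyphenyl in place of 2-chlorophenyl on an aromatic carbon. For the measured compounds named here, this undoes the move of the substituent and swaps the group, so the only measured step bears on it indirectly: a 4-substituted phenyl, as in compound 1 with 3280 nM, gave a clearly lower number than compound 2. Compound 3 is expected to show an at least 3.7-fold lower number from compound 2 to compound 3 (0.57 log units; beyond the scatter), landing at an estimated 8000 nM with a range of 2000 nM to 30000 nM.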

Compound 3, half-maximal inhibitory concentration: 1330 nM
Beside the measured number, compound 3's estimate is 6.0-fold (0.78 log units) above it, and the stated range ends above it.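

In this assay, a 4-substituted phenyl group does not depend on the nitro group for its activity: methoxy in place of nitro gives a 2.5-fold lower number from compound 1 to compound 3 (0.39 log units; beyond the scatter). Exchanging 2-chlorophenyl for 4-methoxyphenyl gives an at least 22-fold lower number from compound 2 to compound 3 (1.35 log units; beyond the scatter), so a 4-substituted phenyl group has now read clearly lower than 2-chlorophenyl with two different substituents. Compound 2 has only a limit of the assay and not a number, which makes that step a lower bound: the limit of > 30000 nM in this assay, at which 1 of the 3 values shown sits.

On these data alone, what a 4-chlorophenyl or a 2-methoxyphenyl group would give remains open, so the place of the substituent cannot yet be separated from its identity. Also open, as far as these compounds go, is how a 4-aminophenyl or a 4-carboxyphenyl group would read in this assay, and the values give no reason for the order seen.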